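Compound 4: bromo in place of 4-fluorophenyl

The source may report more compounds than this note shows. Statements on the series, on what has been measured and on what is new or still open speak of the compounds shown alone.

In an ADME assay on HCT-116 cells (Homo sapiens) for cytotoxicity, read by CellTiter-Glo, with a stated time of 72 h (a higher number here means a weaker inhibitor, a lower number a stronger inhibitor), compound 3 (`CC1CCN(C2CCN(S(=O)(=O)c3cccc(-c4ccc(F)cc4)c3)CC2)CC1`) gives > 5000 nM as a limit. Compound 1 (`CC1CCN(C2CCN(S(=O)(=O)c3cccc(-c4ccccc4F)c3)CC2)CC1`) gives > 5000 nM as a limit too. Compound 2 (`CC1CCN(C2CCN(S(=O)(=O)c3cccc(Cl)c3)CC2)CC1`) likewise gives > 5000 nM as a limit. The series therefore stands at the limit of > 5000 nM in this assay, at which 3 of the 3 values shown sit, and shows no number yet.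

Compound 4 (`CC1CCN(C2CCN(S(=O)(=O)c3cccc(Br)c3)CC2)CC1`) carries bromo in place of 4-fluorophenyl on an aromatic carbon. The nearest measured change is a step that the two limits leave unreadable from compound 2 to compound 3 run the other way and with chloro rather than bromo, and a step that the two limits leave unreadable from compound 1 to compound 2 is of the same kind, so neither gives a size to carry over. In this assay no step beyond the scatter is expected. The estimated change is a step that the limit leaves unreadable from compound 3 to compound 4 with no direction expected. Compound 4 is expected at 7000 nM (estimated range 3000 nM to 15000 nM).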

Compound 4, half-maximal inhibitory concentration: > 5000 nM
Compound 4 was reported as a limit; the forecaster's own chance of this, stated with the estimate: 85%; the middle value lies beyond the limit too.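

No step can be read between compound 4 and compounds 1, 2 or 3 in this assay, because all four stand at one limit: the limit of > 5000 nM in this assay, at which 4 of the 4 values shown sit.

On these data alone, whether any group on this aromatic carbon gives a readable value stays open.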